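The source may hold more compounds than are shown below. What is called first, only, known or untested is meant among the compounds shown, and "the series" means these compounds.

Compound 1 `Nc1ncnc2c1c(I)cn2COC(CO)CO`: 2800 nM in a functional assay on L1210 cells (Mus musculus) for inhibition; on this read-out lower numbers stand for stronger inhibition and higher numbers for weaker inhibition
Compound 2 `Cc1cn(COC(CO)CO)c2ncnc(N)c12`: > 100000 nM in this assay

Compound 2 gives only a limit in this assay, the figure > 100000 nM (the limit of > 100000 nM in this assay, at which 1 of the 2 values shown sits), so its true value is not known, only that it lies beyond that boundary. The step of an at least 35-fold higher number from compound 1 to compound 2 (1.55 log units; beyond the scatter) shows how far the methyl carries the number away from the iodo compound. Compound 3 `Nc1ncnc2c1c(Br)cn2COC(CO)CO` is the next step, in which the methyl is removed again: bromo in place of methyl on an aromatic carbon. Going by the values given here, since the only measured step that bears on this position is the large one an at least 35-fold higher number from compound 1 to compound 2 (1.55 log units; beyond the scatter), and that step ran from a halogen to methyl, the reverse direction, methyl to bromo, is expected to bring the number back down by a large margin, an at least 25-fold lower number from compound 2 to compound 3 (1.39 log units; beyond the scatter), toward where compound 1 stands. For compound 3 the estimate is therefore 4000 nM, with a range from 800 nM to 30000 nM.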

Compound 3, half-maximal inhibitory concentration: 710 nM
Compound 3: the middle estimate sits 5.6-fold (0.75 log units) above what was measured, outside the stated range (below it).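

Bromo gives the strongest inhibition of the three groups at this aromatic carbon in this assay. The two halogens are not interchangeable here, as replacing iodo with bromo gives a 3.9-fold lower number from compound 1 to compound 3 (0.60 log units; beyond the scatter), a modest step but one that still matters. Replacing methyl with bromo gives a much larger change, an at least 140-fold lower number from compound 2 to compound 3 (2.14 log units; beyond the scatter), but the size of that step is only a bound, as compound 2 stands as a limit and not a number: the limit of > 100000 nM in this assay, at which 1 of the 3 values shown sits.

Three groups on one carbon do not reveal what sets this order. The data leave open what separates bromo from iodo. Chloro, an amine or an ethyl chain at the same place would show whether the fall in the number from iodo to bromo continues or whether bromo is the best fit among such groups.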